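A few compounds are considered here, and "the series" means these few. Any claim that something is new, unique, unknown or untested is made for them only; others in the source may bear on it.

Of the compounds shown here, two have so far been measured in an ADME assay on L02 cells (Homo sapiens) for cytotoxicity, read by MTT assay, with a stated time of 24 h; a lower number here means a stronger inhibitor, a higher number a weaker inhibitor. Compound 1 (`CN1C/C(=C\c2ccncc2)C(=O)/C(=C/c2ccccc2F)C1`) gives 14900 nM, and compound 2 (`CN1C/C(=C\c2ccncc2)C(=O)/C(=C/c2ccccc2C(F)(F)F)C1`) gives 15800 nM. These numbers lie within the scatter of each other, so compound 2 stands level with compound 1. Compound 3 (`O=C1/C(=C/c2ccncc2)CNC/C1=C\c1ccccc1C(F)(F)F`) has not yet been measured and differs from compound 2 in one place: hydrogen in place of methyl on an amine nitrogen in a ring. In words, this is hydrogen in place of methyl on an amine nitrogen in a ring.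

Going by the values given here, only one measured step is available as a guide: a 1.1-fold higher number from compound 1 to compound 2 (0.03 log units; within the scatter). That step has trifluoromethyl in place of fluoro on an aromatic carbon, so it does not test a change on the amine nitrogen. Among the compounds with values here, it shows only that one substituent swap elsewhere in the molecule stayed within the scatter. With no measured change at the nitrogen, no step beyond the scatter is expected in this assay, though this expectation is loose. The estimate means a 1.1-fold lower number from compound 2 to compound 3 (0.02 log units; within the scatter), an expected step that stays within the scatter. The estimated value for compound 3 is 15000 nM, with an expected range from 6000 nM to 38000 nM.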

Compound 3, half-maximal inhibitory concentration: 13400 nM
For compound 3 the middle estimate is 1.1-fold (0.05 log units) above the measured one, within the range that was stated.
By their numbers in this assay, from the lowest: compounds 3, 1 and 2 (each within the scatter of the next).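

Going by these compounds alone, compound 3 gives the first measured look at a change on the amine nitrogen in the ring: in this assay, hydrogen in place of methyl gives a 1.2-fold lower number from compound 2 to compound 3 (0.07 log units; within the scatter) and stays within the scatter. For this one pair, which carries trifluoromethyl on the aromatic carbon, the methyl on that nitrogen can therefore be replaced by hydrogen with no readable difference in the number, so the nitrogen joins the aromatic substituent as a second place where a single change has left the value level. No available measurement bears on why the value holds at this position.

This single pair cannot show whether the same replacement would behave alike with fluoro on the aromatic carbon, or whether the nitrogen tolerates anything other than methyl and hydrogen. An ethyl, benzyl or acetyl group on that nitrogen could still move the number beyond the scatter, and so the level values seen here describe only the small change from methyl to hydrogen, not this position in general.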